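Trifluoromethyl on the phenolic oxygen of compound 2

A few compounds are considered here, and "the series" means these few. Any claim that something is new, unique, unknown or untested is made for them only; others in the source may bear on it.

Going by the values given here, compound 2 `Nc1nc(N)c2nc(Nc3ccc(O)cc3)ccc2n1` gives 1580 nM in an ADME assay on isolated protein for inhibition of Dihydrofolate reductase (Homo sapiens), using NADPH (a higher number here means a weaker inhibitor, a lower number a stronger inhibitor), and stands highest of the two numbers measured so far, though its nearest neighbour, compound 1 `Nc1nc(N)c2nc(Nc3ccccc3)ccc2n1` with 1530 nM, lies within the scatter of it. Among the compounds with values here, the one measured step, a 1.0-fold higher number from compound 1 to compound 2 (0.01 log units; within the scatter), is the only one that touches the same oxygen and it produced no change beyond the scatter. Compound 3 `Nc1nc(N)c2nc(Nc3ccc(OC(F)(F)F)cc3)ccc2n1` differs from compound 2 by trifluoromethyl in place of hydrogen on an oxygen on an aromatic ring. Within the data shown here, no measured step shows what adding a trifluoromethyl here does, so the evidence rests on the single step at that position, which was flat. Compound 3 is therefore expected to show no step beyond the scatter, a 1.0-fold higher number from compound 2 to compound 3 (0.01 log units; within the scatter). For compound 3 the estimate in this assay is 1600 nM, with a range from 600 nM to 4500 nM.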

Compound 3, half-maximal inhibitory concentration: 4130 nM
Beside the measured number, compound 3's estimate is 2.6-fold (0.41 log units) below it, and the stated range covers the measured number.
By their numbers in this assay, from the lowest: compounds 1 and 2 (each within the scatter of the next); then compound 3.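

At this oxygen on an aromatic ring, the position does respond in this assay: putting trifluoromethyl on the oxygen gives a 2.6-fold higher number from compound 2 to compound 3 (0.42 log units; beyond the scatter), whereas the earlier change of hydrogen to hydroxy stayed flat at a 1.0-fold higher number from compound 1 to compound 2 (0.01 log units; within the scatter). Read against the compound with no substituent at this place, trifluoromethoxy gives a 2.7-fold higher number from compound 1 to compound 3 (0.43 log units; beyond the scatter), so the weakening is modest and appears from either reference compound. Nothing available bears on the reason for this rise.

The compounds shown leave open whether a methyl or a longer alkyl chain on this oxygen would raise the number as trifluoromethyl does. They also leave open whether an amine or a carboxylic acid in place of the hydroxy would stay flat or bring the number below that of compound 1.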